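This account rests on a few compounds, and the source may have more. Where it says the series, first, only, none or still open, it means among the compounds named here.

Compound 1 `C[C@@H](O[C@@H]1CN(C(=O)[C@@H]2CCC(=O)N2C)C[C@H]1c1ccc(F)cc1)c1cc(C(F)(F)F)cc(C(F)(F)F)c1` gives 0.12 nM in an assay on CHO cells for displacement of a labelled ligand from Substance-P receptor (Homo sapiens); a lower number here means a stronger inhibitor, a higher number a weaker inhibitor.
Compound 2 `CCNC(=O)N1C[C@@H](O[C@H](C)c2cc(C(F)(F)F)cc(C(F)(F)F)c2)[C@H](c2ccc(F)cc2)C1` gives 0.1 nM in this assay.

Among the measured compounds shown here, only two compounds have been measured, and compound 2 sits alongside compound 1: the step of a 1.2-fold lower number from compound 1 to compound 2 (0.08 log units; within the scatter). So swapping the group on the ring nitrogen of the shared core has, so far, left the number where it was.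

Compound 3 `CC1=C(N2C[C@@H](O[C@H](C)c3cc(C(F)(F)F)cc(C(F)(F)F)c3)[C@H](c3ccc(F)cc3)C2)CCC1=O` takes this further: 2-methyl-3-oxocyclopent-1-en-1-yl in place of ethylcarbamoyl on an amine nitrogen in a ring. For the measured compounds named here, the one measured step on this nitrogen bears on it and was flat, but the entering group is of a different kind, so the expectation is loose. The estimated step is a 3.0-fold higher number from compound 2 to compound 3 (0.48 log units; beyond the scatter) for compound 3, expected to give 0.3 nM (range 0.08 nM to 1.5 nM).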

Compound 3, half-maximal inhibitory concentration: 0.13 nM
For compound 3 the middle estimate is 2.3-fold (0.36 log units) above the measured one; the range from low to high includes it.
By their numbers in this assay, from the lowest: compounds 2, 1 and 3 (each within the scatter of the next).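

A different kind of group fits on the amine nitrogen in a ring without moving the number: 2-methyl-3-oxocyclopent-1-en-1-yl, with its five-membered ring of carbon only and 0 hydrogen-bond donors, replaces ethylcarbamoyl, with 1 hydrogen-bond donor (a 1.3-fold higher number from compound 2 to compound 3 (0.11 log units; within the scatter)). Set against the larger acyl group of compound 1, it also stays level (a 1.1-fold higher number from compound 1 to compound 3 (0.03 log units; within the scatter)). No measurement here gives a reason for this flatness.

All three groups on this nitrogen contain a carbonyl. On these data alone, whether a plain ethyl chain or an aminoethyl chain would hold the number stays open.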